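Chloro to Bromo on the Pendant Phenyl Ring

The compounds below may be only part of what the source reports. "The series", "measured", "known", "first", "only" and "open" are said of these compounds alone.

Among the measured compounds shown here, compound 2 `CCCNC(=O)c1cc(Oc2ccc(NC(=O)c3cc4cccnc4n(-c4ccc(Cl)cc4)c3=O)cc2)ccn1` gives 120 nM in a functional assay on A549 cells (Homo sapiens) for antiproliferative activity, read by MTT assay, with a stated time of 72 h (a lower number here means a stronger inhibitor, a higher number a weaker inhibitor), which is the lower of the two numbers measured so far. Compound 1 `CCCNC(=O)c1cc(Oc2ccc(NC(=O)c3cc4cccnc4n(-c4ccccc4F)c3=O)cc2)ccn1` gives 150 nM in this assay, and the step of a 1.3-fold lower number from compound 1 to compound 2 (0.10 log units; within the scatter) is within the scatter, so the two compounds stand together rather than apart. Compound 3 `CCCNC(=O)c1cc(Oc2ccc(NC(=O)c3cc4cccnc4n(-c4ccc(Br)cc4)c3=O)cc2)ccn1` has not yet been measured. It differs from compound 2 by bromo in place of chloro on an aromatic carbon, in words bromo in place of chloro on an aromatic carbon, para to a large group. For the measured compounds named here, no measured step exchanges one halogen for another at this position; the only step available, a 1.3-fold lower number from compound 1 to compound 2 (0.10 log units; within the scatter), concerns the whole aryl group on the aromatic nitrogen, and it was itself within the scatter. With nothing in the measured steps pointing to a shift in either direction, compound 3 is expected to show no step beyond the scatter, and the step of a 1.1-fold lower number from compound 2 to compound 3 (0.04 log units; within the scatter) is the estimate. Compound 3 is therefore estimated at 110 nM, with a range from 50 nM to 250 nM.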

Compound 3, half-maximal inhibitory concentration: 150 nM
Beside the measured number, compound 3's estimate is 1.4-fold (0.13 log units) below it; the range from low to high includes it.
By their numbers in this assay, from the lowest: compounds 2, 1 and 3 (each within the scatter of the next).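

This is the only step shown that exchanges one halogen for another at this position, and in this assay bromo in place of chloro, on an aromatic carbon para to a large group, stays within the scatter (a 1.3-fold higher number from compound 2 to compound 3 (0.10 log units; within the scatter)). The step that exchanges the whole aryl group on the aromatic nitrogen, 4-bromophenyl in place of 2-fluorophenyl, also stays within the scatter (no change at the digits printed from compound 1 to compound 3 (within the scatter)), as does the earlier step to the 4-chlorophenyl group (a 1.3-fold lower number from compound 1 to compound 2 (0.10 log units; within the scatter)), so the three aryl groups shown cannot be told apart in this read-out. No measurement shown alongside these numbers offers an explanation for them.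

The compounds shown leave open whether a step beyond the scatter would appear with a group of another kind at this place on the phenyl ring, such as a methoxy group, an amine or a carboxylic acid. They also leave open how iodo at this same place, or an unsubstituted phenyl ring on the aromatic nitrogen, would stand against these three compounds.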